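The source may report more compounds than this note shows. Statements on the series, on what has been measured and on what is new or still open speak of the compounds shown alone.

Three compounds share one core and differ only in the aryl group attached to it. Compound 1 `Cc1cc(-c2cccc(C(F)(F)F)c2)cc(C)c1Nc1ccnc(Nc2ccc(C#N)cc2)n1` carries a 3-(trifluoromethyl)phenyl group and in an ADME assay on MT4 cells (Homo sapiens) for cytotoxicity, read by MTT assay, with a stated time of 4 days (on this read-out lower numbers stand for higher toxicity in this test and higher numbers for lower toxicity in this test), compound 1 gives 4030 nM. Compound 2 `Cc1cc(-c2cccc(Cl)c2)cc(C)c1Nc1ccnc(Nc2ccc(C#N)cc2)n1` carries a 3-chlorophenyl group, and in this assay compound 2 gives 2160 nM. Compound 3 `Cc1cc(C)cc(-c2cc(C)c(Nc3ccnc(Nc4ccc(C#N)cc4)n3)c(C)c2)c1` carries a 3,5-dimethylphenyl group, and in this assay compound 3 gives 4140 nM. On these numbers compound 3 stands together with the other two: the step of a 1.0-fold higher number from compound 1 to compound 3 (0.01 log units; within the scatter) and the step of a 1.9-fold higher number from compound 2 to compound 3 (0.28 log units; within the scatter) both stay inside the scatter, as does the step of a 1.9-fold lower number from compound 1 to compound 2 (0.27 log units; within the scatter).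

Compound 4 `Cc1ccccc1-c1cc(C)c(Nc2ccnc(Nc3ccc(C#N)cc3)n2)c(C)c1` differs from compound 3 by a single exchange at the same position: 2-methylphenyl in place of 3,5-dimethylphenyl on an aromatic carbon. All three measured steps concern exactly this aryl group, and none of them left the scatter, so no evidence suggests that this position moves the read-out of this assay. Accordingly the step of a 1.1-fold lower number from compound 3 to compound 4 (0.04 log units; within the scatter) is expected to remain within the scatter. For compound 4 in this assay the estimate is 3800 nM, with a range from 1900 nM to 7600 nM, the uncertainty reflecting only the spread seen among compounds 1, 2 and 3.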

Compound 4, half-maximal cytotoxic concentration: 3820 nM
The estimate for compound 4 lay 1.0-fold (0.00 log units) below the measured number; low and high end bracket the measured number.
By their numbers in this assay, from the lowest: compounds 2, 4, 1 and 3 (each within the scatter of the next).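

In this assay the 2-methylphenyl group joins the other aryl groups without any step leaving the scatter, whether it is set against 3,5-dimethylphenyl (a 1.1-fold lower number from compound 3 to compound 4 (0.03 log units; within the scatter)), 3-chlorophenyl (a 1.8-fold higher number from compound 2 to compound 4 (0.25 log units; within the scatter)) or 3-(trifluoromethyl)phenyl (a 1.1-fold lower number from compound 1 to compound 4 (0.02 log units; within the scatter)). The earlier compounds shown here held only groups named with a substituent at 3 or at 3 and 5, so compound 4 adds a differently substituted phenyl group, and the read-out at this position still shows no step beyond the scatter across the four compounds. Nothing available here offers an explanation for this flat result.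

The four compounds leave open whether an amine or a carboxylic acid on this aryl group would carry the number beyond the scatter, as all the substituents shown are methyl, chloro or trifluoromethyl. They also leave open whether a change elsewhere on the shared core, such as replacing the nitrile with a carboxylic acid, would move this read-out, as all four keep that part unchanged.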